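A Formyl Cap on the Amine of Compound 2

The source may report more compounds than this note shows. Statements on the series, on what has been measured and on what is new or still open speak of the compounds shown alone.

Compound 1 `COC(=O)CNC(=O)C(CSCc1ccc(Br)cc1)NC(=O)CCC(N)C(=O)O`: > 50 uM
Compound 2 `COC(=O)CNC(=O)C(CSCc1ccc(Br)cc1)NC(=O)CCC(N)C(=O)OC`: > 50 uM

Compound 2 sits at a limit of the assay in a functional assay on K562 cells (Homo sapiens) for cytotoxicity (on this read-out higher numbers stand for weaker inhibition and lower numbers for stronger inhibition), where its value > 50 uM is not a number. Compound 1 likewise gives only a limit, > 50 uM. Both rest at the limit of > 50 uM in this assay, at which 2 of the 2 values shown sit, so the step that the two limits leave unreadable from compound 1 to compound 2 cannot be read. Compound 3 `COC(=O)CNC(=O)C(CSCc1ccc(Br)cc1)NC(=O)CCC(NC=O)C(=O)OC` differs from compound 2 by formyl in place of hydrogen on an amine nitrogen. No measured step bears readably on this change, and nothing shown argues that the limit will be left. Compound 3 is therefore expected at 60 uM, within 20 uM to 200 uM. The expected step is a step that the limit leaves unreadable from compound 2 to compound 3.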

Compound 3, concentration for 50% inhibition: > 50 uM
Compound 3 ended at the assay's limit; the forecaster's own chance of this, stated with the estimate: 85%; the middle value lies beyond the limit too.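

In this assay compound 3 gives > 50 uM as a limit and not a number. For the compounds shown here, no step among compound 1, compound 2 and compound 3 can be read: the limit of > 50 uM in this assay, at which 3 of the 3 values shown sit. From the compounds shown here alone, whether formyl in place of hydrogen on the amine nitrogen changes inhibition at all stays open.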